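From Fluoro to Trifluoromethyl on a Shared Core

This account rests on a few compounds, and the source may have more. Where it says the series, first, only, none or still open, it means among the compounds named here.

Compound 1, `COc1cc2ncnc(Nc3cc(C(F)(F)F)ccc3F)c2c(OC)c1OC`, gives 7.6% in a functional assay on PC-3 cells (Homo sapiens) for inhibition, read by MTT assay, with a stated time of 72 h, tested at 1 uM; a lower number here means less inhibition of growth, a higher number more inhibition of growth at the concentration tested.
Compound 2, `COc1cc2ncnc(Nc3cccc(C(F)(F)F)c3)c2c(OC)c1OC`, gives 14.9% in this assay.
Compound 3, `COc1cc2ncnc(Nc3cc(F)ccc3Br)c2c(OC)c1OC`, gives 12.8% in this assay.

All three compounds share one core and differ only in the groups on one aromatic ring. Compound 3 stands second highest of the three numbers; its nearest neighbour is compound 2 and its furthest is compound 1, and both gaps lie within the usual scatter of this assay, so the three numbers cannot be told apart.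

Compound 4, `COc1cc2ncnc(Nc3cc(C(F)(F)F)ccc3Br)c2c(OC)c1OC`, has not yet been measured. It arises from compound 3 by a single change: trifluoromethyl in place of fluoro on an aromatic carbon. For the measured compounds named here, the one step so far between compounds that differ in one place, a number 7.3 percentage points higher from compound 1 to compound 2 (within the scatter), exchanges fluoro for hydrogen on a ring that already carries trifluoromethyl, and it stays within the scatter; it does not directly cover the present exchange. What can be said is that compound 1 and compound 2, both bearing trifluoromethyl, sit as low as compound 3 with its fluoro. The expected step is therefore small, a number 0.8 percentage points lower from compound 3 to compound 4 (within the scatter), with no movement beyond the scatter. Compound 4 is estimated to give 12% in this assay, somewhere between 3% and 22%.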

Compound 4, percent growth inhibition at one concentration: -3.9%
Compound 4: the middle estimate sits 15.9 percentage points above what was measured, and the stated range ends above it.
By their numbers in this assay, from the lowest: compound 4; then compounds 1, 3 and 2 (each within the scatter of the next).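

For the compounds shown here, on the ring that carries bromo, at the carbon para to the bromo group, trifluoromethyl in place of fluoro gives a number 16.7 percentage points lower from compound 3 to compound 4 (beyond the scatter) in this assay, the first step between these compounds to pass beyond the scatter. The bromo group matters as well: with trifluoromethyl kept in place, bromo in place of hydrogen gives a number 18.8 percentage points lower from compound 2 to compound 4 (beyond the scatter), and bromo in place of fluoro gives a number 11.5 percentage points lower from compound 1 to compound 4 (beyond the scatter). So trifluoromethyl without bromo (compound 1 and compound 2) and bromo without trifluoromethyl (compound 3) leave the numbers within the scatter of their neighbours, and only compound 4, which carries both groups, falls clearly lower, though no measurement shown here explains this.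

From the compounds shown here alone, it remains open whether this drop is specific to trifluoromethyl or would also appear with another group at that carbon, such as a methyl group, an amine or a carboxylic acid, and whether chloro in place of bromo would give the same result. All four numbers also come from a single concentration in one cell line, so the compounds shown cannot tell whether the drop would hold under other conditions.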